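Bromo in Place of Methyl on a Weak Inhibitor

This account rests on a few compounds, and the source may have more. Where it says the series, first, only, none or still open, it means among the compounds named here.

compound 1 `Cc1ccc(N2C(=O)C=CC2OCC(F)(F)F)cc1` — 13700 nM
compound 2 `O=C1C=CC(OCC(F)(F)F)N1c1cc(F)cc(F)c1` — 5000 nM
compound 3 `CC(C)NC1CC(=O)N(c2ccc(F)c(Cl)c2)C1OCC(F)(F)F` — > 100000 nM (a limit)

Three compounds sharing one core were tested in a functional assay on A549 cells (Homo sapiens) for inhibition; on this read-out lower numbers stand for stronger inhibition and higher numbers for weaker inhibition. Compound 1 gives 13700 nM, the higher of the two numbers shown, while compound 2 with 5000 nM sits a step below it that is beyond the usual scatter. For compound 3 the value > 100000 nM is a limit of the assay rather than a number (the limit of > 100000 nM in this assay, at which 1 of the 3 values shown sits). Compound 4 `O=C1C=CC(OCC(F)(F)F)N1c1ccc(Br)cc1` differs from compound 1 in one place: bromo in place of methyl on an aromatic carbon. Within the data shown here, no measured pair here differs in only one place, so the size of such a step cannot be read from the data. Compound 4 is expected to give about 8000 nM, with a likely range from 3000 nM to 30000 nM. The expected step of a 1.7-fold lower number from compound 1 to compound 4 (0.23 log units; within the scatter) is a small one toward stronger inhibition, if any beyond the scatter.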

Compound 4, half-maximal inhibitory concentration: 6960 nM
The estimate for compound 4 lay 1.1-fold (0.06 log units) above the measured number; the measured number falls inside the stated range.
By their numbers in this assay, from the lowest: compounds 2, 4 and 1 (each within the scatter of the next, the first and the last beyond it). At a limit, above all of these: compound 3.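

Among these compounds, the swap of methyl for bromo gives the first step in this set that differs in one place, and in this assay it reads a 2.0-fold lower number from compound 1 to compound 4 (0.29 log units; within the scatter), so the two groups cannot be told apart at this position on the aromatic ring. This single swap therefore gives no sign that the read-out responds to a change at this position. Nothing shown here bears on why the two groups read alike.

From the compounds shown here alone, whether an amine or a carboxylic acid in this place would give a step beyond the scatter remains open. So does the effect of a plain hydrogen or a longer chain there.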